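Trading a Methyl for Hydrogen

The source may report more compounds than this note shows. Statements on the series, on what has been measured and on what is new or still open speak of the compounds shown alone.

In a physicochemical assay for lipophilicity, at pH 7.4 (a higher number here means a more lipophilic compound, a lower number a more polar compound), compound 1 (`COc1cccc(C(=O)NCc2c(C)cc(C)[nH]c2=O)c1F`) gives 1.4 while compound 2 (`Cc1cc(C)c(CN2CCc3c(Cl)cc(-c4c(C)n[nH]c4C)c(Cl)c3C2=O)c(=O)[nH]1`) gives 3.4 and so stands the higher of the two, beyond the usual scatter. Compound 3 (`Cc1cc(C)c(CN2CCc3c(Cl)cc(-c4cn[nH]c4C)c(Cl)c3C2=O)c(=O)[nH]1`) has hydrogen in place of methyl on an aromatic carbon, turning 3,5-dimethyl-1H-pyrazol-4-yl into 5-methyl-1H-pyrazol-4-yl. Going by the values given here, no measured pair shows this change, so a small fall in this assay is expected, possibly within the scatter. The expected size is a number 0.30 log units lower from compound 2 to compound 3 (within the scatter) on this estimate. Compound 3 is estimated at 3.1 with an expected range from 2.7 to 3.4 in all.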

Compound 3, distribution coefficient: 3.1
For compound 3 middle estimate and measured number coincide at the digits printed, within the range that was stated.
By their numbers in this assay, from the lowest: compound 1; then compounds 3 and 2 (each within the scatter of the next).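

In this assay, going by these compounds alone, the change from 3,5-dimethyl-1H-pyrazol-4-yl to 5-methyl-1H-pyrazol-4-yl gives a number 0.30 log units lower from compound 2 to compound 3 (within the scatter) and is the first step that isolates this position. Compound 1 and compound 2 differ in more than one place, so they could not show that hydrogen in place of this one methyl stays within the usual scatter. No independent measurement is available to explain this result.

Still open, from the compounds shown here alone, is whether the remaining methyl on this ring behaves the same way. Also open, going by these compounds, is how an amine or a carboxylic acid at this position would read in this assay.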